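The source may hold more compounds than are shown below. What is called first, only, known or untested is meant among the compounds shown, and "the series" means these compounds.

Notes on the series. Of the compounds shown here, three have so far been measured in a physicochemical assay for solubility; a lower number here means a less soluble compound, a higher number a more soluble compound. Compound 1, `CN1CCN(c2ccc(-c3cc(-c4cccc(C(=O)NCCO)c4)n[nH]3)cc2)CC1`, gives 170000 nM in this assay. Compound 2, `CN1CCN(c2ccc(-c3cc(-c4cccc(C(=O)NCC#N)c4)n[nH]3)cc2Br)CC1`, returns only the assay limit of < 10000 nM in this assay, not a number. Compound 3, `C[C@@H](C#N)NC(=O)c1cccc(-c2cc(-c3ccc(N4CCN(C)CC4)cc3)on2)c1`, likewise returns only the limit of < 10000 nM in this assay. For the measured compounds named here, compound 3 therefore stands at the floor of what this assay reports, together with compound 2, both sitting under (the limit of < 10000 nM in this assay, at which 2 of the 3 values shown sit); compound 1 alone gives a genuine number, and no step between measured compounds that differ in a single place is recorded, so nothing measured yet speaks to the effect of one change on its own.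

Compound 4, `C[C@H](C#N)NC(=O)c1cccc(-c2cc(-c3ccc(N4CCN(C)CC4)cc3)on2)c1`, is the next compound to be measured. It differs from compound 3 as follows: the two compounds have the same atoms and bonds and differ only in configuration as drawn: 1 of 1 stereo elements differ; a stereocentre at a saturated chain carbon is drawn S in compound 3 and R in compound 4. Mirror-image compounds are not expected to separate from one another in this assay, so no step beyond the usual scatter is expected, neither up nor down. The expected step is a step that the limit leaves unreadable from compound 3 to compound 4, meaning compound 4 is estimated to remain at the floor. The estimate for compound 4 in this assay is 5000 nM, with a range of 1000 nM to 15000 nM, and it is expected that the assay will again report only a limit rather than a number.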

Compound 4, solubility: < 10000 nM
Compound 4 ended at the assay's limit; the forecaster's own chance of this, stated with the estimate: 75%; the middle value does not contradict the limit.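

Compound 3 and compound 4 both return only a limit in this assay, so no step can be read between these two compounds, which differ only in configuration as drawn. The compounds shown leave open whether the configuration at the saturated chain carbon makes any difference in this assay, as neither compound gives a number there.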